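Replacing azido in a small antiproliferative series

The source may report more compounds than this note shows. Statements on the series, on what has been measured and on what is new or still open speak of the compounds shown alone.

Measured so far in a functional assay on A549 cells (Homo sapiens) for antiproliferative activity, read by MTT assay, with a stated time of 48 h; on this read-out higher numbers stand for weaker inhibition and lower numbers for stronger inhibition:
- compound 1 `CC(C)=CCC[C@]1(C)/C=C/[C@@H](OC(=O)C=C(C)C)[C@](C)(O)/C=C/C(=O)/C(C[Si](C)(C)C(C)(C)C)=C\C1`: 4200 nM
- compound 2 `COCOC/C1=C/C[C@](C)(CCC=C(C)C)/C=C/[C@@H](OC(=O)C=C(C)C)[C@](C)(O)/C=C/C1=O`: 2980 nM
- compound 3 `CC(C)=CCC[C@]1(C)/C=C/[C@@H](OC(=O)C=C(C)C)[C@](C)(O)/C=C/C(=O)/C(CN=[N+]=[N-])=C\C1`: 1720 nM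

Compound 3 sits at the low end of these three values, but only one of its two gaps clears the scatter. That gap is a 2.4-fold lower number from compound 1 to compound 3 (0.39 log units; beyond the scatter), whereas a 1.7-fold lower number from compound 2 to compound 3 (0.24 log units; within the scatter) does not clear it.

The next compound is compound 4 `CSC(=S)OC/C1=C/C[C@](C)(CCC=C(C)C)/C=C/[C@@H](OC(=O)C=C(C)C)[C@](C)(O)/C=C/C1=O`, which keeps the shared core. The change from compound 3 is a group of 5 heavy atoms (2 carbon, 1 oxygen, 2 sulfur; no ring) in place of a group of 3 heavy atoms (3 nitrogen; no ring), on a saturated chain carbon bound to a double-bonded ring carbon.

All three measured steps come from this same place, so all of them bear on the change. The third is a 1.4-fold lower number from compound 1 to compound 2 (0.15 log units; within the scatter), also within the scatter. Three quite different groups have therefore given only small steps, and the largest of these is modest. Among the measured compounds shown here, none of the measured compounds carries the entering group, so the data offer no direct test of it.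

With compound 3 at 1720 nM at the low end of the range, a small drift towards a higher number seems more likely than a further fall. In this assay the expected step is a 1.5-fold higher number from compound 3 to compound 4 (0.16 log units; within the scatter), which means no clear shift beyond the scatter is anticipated.

For compound 4 the estimated value is 2500 nM, with an expected range of 1100 nM to 6000 nM.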

Compound 4, half-maximal inhibitory concentration: 380 nM
Compound 4: the middle estimate sits 6.6-fold (0.82 log units) above what was measured; measured number below the stated range.
By their numbers in this assay, from the lowest: compound 4; then compounds 3, 2 and 1 (each within the scatter of the next, the first and the last beyond it).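

In this assay, among the compounds shown here, this place, a saturated chain carbon bound to a double-bonded ring carbon, proves more responsive than the earlier compounds showed: a 4.5-fold lower number from compound 3 to compound 4 (0.66 log units; beyond the scatter) is the first step beyond the scatter from the lowest earlier value, and an 11-fold lower number from compound 1 to compound 4 (1.04 log units; beyond the scatter) is the widest gap, leaving compound 4 the most potent of the four. The oxygen on the saturated carbon is not enough on its own, since compound 2 carries it too, and a 7.8-fold lower number from compound 2 to compound 4 (0.89 log units; beyond the scatter) comes with a group of 4 heavy atoms (2 carbon, 2 sulfur) on that oxygen in place of a group of 3 heavy atoms (2 carbon, 1 oxygen). No measurement in hand gives a reason for this gain.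

Among the compounds shown, only compound 4 carries sulfur, so it remains open whether the gain needs both sulfur atoms or the terminal methyl. A simple thioether, a carbamate or a longer chain on the sulfur at this same place would separate these possibilities.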